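The source may hold more compounds than are shown below. What is called first, only, known or untested is meant among the compounds shown, and "the series" means these compounds.

Compound 1 `COc1cc(/C=C2\CN(C)C/C(=C\c3ccc(Cl)cc3Cl)C2=O)cc(OC)c1` was examined in a functional assay on THP-1 cells (Homo sapiens) for cytotoxicity, read by MTT assay, with a stated time of 24 h (a lower number here means a stronger inhibitor, a higher number a weaker inhibitor), where compound 1 gives 6070 nM. Compound 2 `COc1cc(/C=C2\CN(C)C/C(=C\c3ccc(Cl)c(Cl)c3)C2=O)cc(OC)c1` differs from it by 3,4-dichlorophenyl in place of 2,4-dichlorophenyl on a double-bonded chain carbon bound to a double-bonded ring carbon, and in this assay compound 2 gives 3260 nM, a movement recorded as a 1.9-fold lower number from compound 1 to compound 2 (0.27 log units; within the scatter). Compound 3 `COc1cc(/C=C2\CN(C)C/C(=C\c3ccc(Cl)cc3Cl)C2=O)cc(OC)c1OC` carries a different core, set apart from compound 1 by methoxy in place of hydrogen on an aromatic carbon; in this assay compound 3 gives 5020 nM, so that a 1.2-fold lower number from compound 1 to compound 3 (0.08 log units; within the scatter). Compound 4 `COc1cc(/C=C2\CN(C)C/C(=C\c3ccc(Cl)c(Cl)c3)C2=O)cc(OC)c1OC` stands to compound 3 as compound 2 stands to compound 1, the relation being (3,4-dichlorophenyl in place of 2,4-dichlorophenyl on a double-bonded chain carbon bound to a double-bonded ring carbon), the same change as before. Because that change once produced a 1.9-fold lower number from compound 1 to compound 2 (0.27 log units; within the scatter), a step of similar size is expected here, namely a 1.9-fold lower number from compound 3 to compound 4 (0.27 log units; within the scatter). Compound 4 is accordingly estimated at 2700 nM in this assay, with a likely range from 1300 nM to 5600 nM.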

Compound 4, half-maximal inhibitory concentration: 5330 nM
The estimate for compound 4 lay 2.0-fold (0.30 log units) below the measured number; measured number inside the range.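

In this assay the swap of 2,4-dichlorophenyl for 3,4-dichlorophenyl now gives a 1.1-fold higher number from compound 3 to compound 4 (0.03 log units; within the scatter) and cannot be told apart from its earlier step: the same change on two cores in this assay, a 1.9-fold lower number (0.27 log units; within the scatter) from compound 1 to compound 2 and a 1.1-fold higher number (0.03 log units; within the scatter) from compound 3 to compound 4, 2.0-fold (0.30 log units) apart, within the scatter of two such steps.
Methoxy in place of hydrogen gives a 1.6-fold higher number from compound 2 to compound 4 (0.21 log units; within the scatter) and likewise cannot be told apart from its earlier step: the same change on two cores in this assay, a 1.2-fold lower number (0.08 log units; within the scatter) from compound 1 to compound 3 and a 1.6-fold higher number (0.21 log units; within the scatter) from compound 2 to compound 4, 2.0-fold (0.30 log units) apart, within the scatter of two such steps.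
Both changes therefore carry between these two cores without a detectable difference, but with every step inside the scatter this does not show that either change moves the number at all, or that the steps would hold on any other core.

The compounds shown leave open what a nitrile or a carboxylic acid would do in place of the chlorines. They also leave open the effect of a longer chain in place of the methyl group.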